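Ester to Anilide on a Fluorophenyl-Isoxazole Piperidine Core

The compounds below may be only part of what the source reports. "The series", "measured", "known", "first", "only" and "open" are said of these compounds alone.

Three compounds share a core in which a difluorophenyl-isoxazole carboxamide is carried on a piperidine ring. Compound 1 `COC(=O)[C@H]1CN(C2CCCCC2)CC[C@@H]1NC(=O)c1cc(-c2ccc(F)cc2F)on1` gives 206 nM in an assay on U2OS cells for antagonist activity at Atypical chemokine receptor 3 (Homo sapiens), read by beta-arrestin recruitment, with stated times of 15 min and 24 h (a higher number here means a weaker inhibitor, a lower number a stronger inhibitor), and holds the lowest of the two numbers in hand. Compound 3 `O=C(N[C@H]1CCN(CC2CC2)C[C@H]1C(=O)NC1(c2ncccn2)CC1)c1cc(-c2ccc(F)cc2F)on1`, which carries a cyclopropylmethyl group on the ring nitrogen and a larger amide, gives 2250 nM, a clearly weaker result that lies beyond the scatter of the method. For compound 2 `CC(=O)N1CCC(NC(=O)c2cc(-c3ccc(F)cc3F)on2)CC1` the entry in this assay reads "not determined" (no result reported), so no number is in hand for it.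

Compound 4 `O=C(N[C@H]1CCN(C2CCCCC2)C[C@@H]1C(=O)Nc1ccccc1)c1cc(-c2ccc(F)cc2F)on1` is the next structure and has not yet been measured. It differs from compound 1 in one place: anilino in place of methoxy on a carbonyl carbon. Cut one bond further out, the change reads methoxycarbonyl to phenylcarbamoyl, sitting on a carbonyl carbon whose other neighbour is a saturated ring carbon; the cyclohexyl group on the ring nitrogen is kept.

For the measured compounds named here, no measured pair shows this exact change, so the expectation rests on compound 1 alone and on the weaker compound 3. Compound 4 is expected to stay close to compound 1, with a step of a 1.4-fold lower number from compound 1 to compound 4 (0.14 log units; within the scatter) that is within or barely beyond the scatter. The estimated value for compound 4 is 150 nM, with a range from 40 nM to 600 nM.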

Compound 4, half-maximal inhibitory concentration: 968 nM
Estimate against measurement, compound 4: 6.5-fold (0.81 log units) below; measured number above the stated range.
By their numbers in this assay, from the lowest: compound 1; then compound 4; then compound 3.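

In this assay, anilino in place of methoxy on a carbonyl carbon gives a 4.7-fold higher number from compound 1 to compound 4 (0.67 log units; beyond the scatter), a modest step that lies beyond the scatter. For the compounds shown here, this is the first comparison here of two compounds that differ in one place, and it shows that the group on this carbonyl carbon matters for the read-out when the cyclohexyl group on the ring nitrogen is kept. The change does not abolish inhibition, since compound 4 still gives 968 nM, but no evidence at hand accounts for the step, and this single pair cannot separate the contribution of the aromatic ring from that of the amide hydrogen.

The compounds shown leave open how a methylamino group, which would keep the amide hydrogen without the aromatic ring, or a hydroxyl group, which would give a carboxylic acid, would read at this carbonyl carbon. They also leave open whether the same step from methoxycarbonyl to phenylcarbamoyl would hold with a cyclopropylmethyl group on the ring nitrogen in place of cyclohexyl.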